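Cyclohexyl Ester in Place of the Isopropylamide

The compounds below may be only part of what the source reports. "The series", "measured", "known", "first", "only" and "open" are said of these compounds alone.

For the measured compounds named here, compound 2 `CC1=C(C(=O)NC(C)C)C(c2ccoc2)NC(=O)N1` gives 3% in an assay on membranes from HeLa cells for displacement of a labelled ligand from adenosine receptor A3 (Homo sapiens), read by scintillation counting, with a stated time of 180 min, tested at 1 uM (a higher number here means more inhibition at the concentration tested (going by the name of the read-out), a lower number less inhibition), and the one other number, from compound 1 `COC(=O)C1=C(C)NC(=O)NC1c1ccoc1` with 2%, sits within the scatter of it, as the step of a number 1 percentage points higher from compound 1 to compound 2 (within the scatter) shows. Compound 3 `CC1=C(C(=O)OC2CCCCC2)C(c2ccoc2)NC(=O)N1` differs from compound 2 in one place: cyclohexyloxy in place of isopropylamino on a carbonyl carbon. Going by the values given here, the single measured step bears on this change, since it also exchanged the group on a carbonyl carbon and stayed within the scatter. No step beyond the scatter is therefore expected for compound 3, no change at the digits printed from compound 2 to compound 3 (within the scatter). Compound 3 is estimated at 3%, in a range from -5% to 12%.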

Compound 3, a percentage reported as inhibition, at one concentration (the size of the read-out at that concentration, not a potency): 1%
Estimate against measurement, compound 3: 2 percentage points above, within the range that was stated.
By their numbers in this assay, from the lowest: compounds 3, 1 and 2 (each within the scatter of the next).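

In this assay, the cyclohexyloxy group gives a number 2 percentage points lower from compound 2 to compound 3 (within the scatter), and cyclohexyl in place of methyl on an oxygen next to a carbonyl group gives a number 1 percentage points lower from compound 1 to compound 3 (within the scatter). Thus neither a six-membered non-aromatic ring at this carbonyl carbon nor the exchange of the amide hydrogen for an oxygen there moves the number beyond the scatter. Nothing available explains this result.

Going by these compounds, whether a carboxylic acid, a benzyl ester or a longer chain on this carbonyl carbon would raise the number stays open. So does whether any change elsewhere on the shared core would do so.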